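The compounds below may be only part of what the source reports. "The series", "measured", "known", "first", "only" and "open" are said of these compounds alone.

Measured so far:
- In a functional assay on U-937 cells (Homo sapiens) for cytotoxicity, read by MTT assay, with a stated time of 48 h (a lower number here means a stronger inhibitor, a higher number a weaker inhibitor), compound 1 (`Fc1cccc(-c2nc(Nc3ccccc3Cl)c3cc(F)ccc3n2)c1`) gives > 50000 nM as a limit, not a number
- In this assay compound 2 (`Fc1cccc(-c2nc(Nc3ccccc3Br)c3cc(F)ccc3n2)c1`) gives > 50000 nM as a limit, not a number

Among the compounds with values here, compound 2 therefore has no exact value, and it shares its limit with the only other measured compound (the limit of > 50000 nM in this assay, at which 2 of the 2 values shown sit). Compound 3 (`Cc1ccc(Nc2nc(-c3cccc(F)c3)nc3ccc(F)cc23)cc1`) carries 4-methylphenyl in place of 2-bromophenyl on a nitrogen on an aromatic ring and keeps the rest of the structure. Within the data shown here, the one measured step, a step that the two limits leave unreadable from compound 1 to compound 2, has no readable size and concerns a different change, so it offers no size or direction to carry over. In this assay no clear shift is expected, and compound 3 may well report only a limit too. The expected change is a number no higher from compound 2 to compound 3 (the limit leaves the size open) on this estimate. Compound 3 is estimated at 50000 nM (expected range 15000 nM to 80000 nM).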

Compound 3, half-maximal inhibitory concentration: > 50000 nM
Compound 3 was reported as a limit; the forecaster's own chance of this, stated with the estimate: 65%; the middle value sits exactly at the limit.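

No step can be read among compound 1, compound 2 and compound 3, as each reports only a limit and not a number in this assay: the limit of > 50000 nM in this assay, at which 3 of the 3 values shown sit.

The compounds shown leave open whether 2-chlorophenyl, 2-bromophenyl and 4-methylphenyl on the nitrogen differ in strength at all.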